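A Third Substituted Phenyl Variant on a Shared Core

The compounds below may be only part of what the source reports. "The series", "measured", "known", "first", "only" and "open" are said of these compounds alone.

Compound 1 `C[C@H](NC(=O)c1c(Cc2cccc(F)c2)sc2c1CCOC2)c1ccc(C(=O)O)cc1`: 5.1 nM
Compound 2 `C[C@H](NC(=O)c1c(Cc2ccc(OC(F)(F)F)c(Cl)c2)sc2c1CCOC2)c1ccc(C(=O)O)cc1`: 6.6 nM

Within the data shown here, in a functional assay on CHO/Galpha16 cells for antagonist activity at prostaglandin E2 receptor EP4 subtype (Homo sapiens), read by calcium flux, with a stated time of 15 min (a higher number here means a weaker inhibitor, a lower number a stronger inhibitor), compound 1 gives 5.1 nM, while compound 2 gives 6.6 nM, the higher of the two numbers; the only step measured so far, a 1.3-fold higher number from compound 1 to compound 2 (0.11 log units; within the scatter), stays within the scatter. Compound 3 `C[C@H](NC(=O)c1c(Cc2cc(F)c(Cl)cc2Cl)sc2c1CCOC2)c1ccc(C(=O)O)cc1` differs from compound 2 by 2,4-dichloro-5-fluorophenyl in place of 3-chloro-4-(trifluoromethoxy)phenyl on a saturated chain carbon bound to an aromatic carbon. Among the measured compounds shown here, that single earlier step is the only one bearing on this change, and it was flat, so no movement beyond the scatter is expected: a 1.1-fold higher number from compound 2 to compound 3 (0.03 log units; within the scatter). Compound 3 is therefore estimated at 7 nM, with a range from 3 nM to 18 nM.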

Compound 3, half-maximal inhibitory concentration: 2.5 nM
Compound 3: middle estimate off by 2.8-fold (0.45 log units), on the high side, outside the stated range (below it).
By their numbers in this assay, from the lowest: compound 3; then compounds 1 and 2 (each within the scatter of the next).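

This position, on a saturated chain carbon bound to an aromatic carbon, does respond to what the phenyl ring carries. In this assay the 2,4-dichloro-5-fluorophenyl group gives a 2.6-fold lower number from compound 2 to compound 3 (0.42 log units; beyond the scatter) and a 2.0-fold lower number from compound 1 to compound 3 (0.31 log units; beyond the scatter) with both steps modest yet beyond the scatter, whereas the earlier swap between phenyl groups moved nothing measurable.

Going by these compounds, whether the ring accepts an amine or a carboxylic acid in place of its halogens stays open, as does which of the three halogens in compound 3 matters most. Nothing measured here explains the lower number.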